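A few compounds are considered here, and "the series" means these few. Any claim that something is new, unique, unknown or untested is made for them only; others in the source may bear on it.

Working notes on the series. Going by the values given here, compound 1, `Nc1nc(Cl)c2ncn(Cc3ccccc3CCl)c2n1`, is the weaker of the two measured members: in a functional assay on T47D cells (Homo sapiens) for cytotoxicity, read by sulforhodamine B assay, with a stated time of 48 h (on this read-out lower numbers stand for stronger inhibition of growth and higher numbers for weaker inhibition of growth), compound 1 gives 83200 nM, the highest of the two numbers recorded. The nearest point is compound 2, `ClCc1cccc(Cn2cnc3nc(Cl)nc(Cl)c32)c1`, for which this assay gives 610 nM; the gap between these two values is beyond the scatter, but the two structures differ in more than one place, so nothing is attributed to any single change here.

Compound 3, `ClCc1ccccc1Cn1cnc2c(Cl)ncnc21`, has not yet been run in this assay. It is reached from compound 1 by one change, (hydrogen in place of amino on an aromatic carbon). Among the compounds with values here, no measured pair isolates this change, so the expectation rests only on the two values above and on the step itself. The amino group is lost; compound 2, the lower of the two numbers, also lacks an amino group at that position, though it carries other differences as well.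

The expected step from compound 1 to compound 3 is a 4.2-fold lower number from compound 1 to compound 3 (0.62 log units; beyond the scatter), a modest move toward a lower number, not more. For compound 3 the estimate is 20000 nM, with a range from 4000 nM to 80000 nM.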

Compound 3, concentration for total growth inhibition: 61700 nM
Beside the measured number, compound 3's estimate is 3.1-fold (0.49 log units) below it; the range from low to high includes it.
By their numbers in this assay, from the lowest: compound 2; then compounds 3 and 1 (each within the scatter of the next).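

In this assay, hydrogen in place of amino on an aromatic carbon, between two ring nitrogen atoms, gives a 1.3-fold lower number from compound 1 to compound 3 (0.13 log units; within the scatter). Going by these compounds alone, this is the first pair that isolates a single change, and it shows no effect on growth inhibition that can be told from the scatter: at this position, on the core of compound 1, the amino group can be lost without a readable consequence. The large gap that separates compound 2 from compound 1 therefore finds no support in this one change, and the differences compound 2 carries elsewhere remain unseparated. No measurement at hand bears on why this position responds so little.

Still open, going by these compounds, is whether this position tolerates everything or only these two substituents, since a methoxy group, a methylamino group or a dimethylamino group in the same place would test the point beyond amino and hydrogen. Within the data shown here, also open is whether the same change would be as silent on the core of compound 2, where no pair isolates it.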